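The source may hold more compounds than are shown below. What is called first, only, known or untested is meant among the compounds shown, and "the series" means these compounds.

Measured so far:
compound 1 `CCCCCCCC(=O)OCCc1c(-c2ccccc2Cl)c2cc(Cl)ccc2[nH]c1=O`: 78000 nM
compound 2 `O=C(OCCc1c(-c2ccccc2Cl)c2cc(Cl)ccc2[nH]c1=O)c1ccco1`: 98000 nM

In an ADME assay on HepG2 2.2.15 cells (Homo sapiens) for cytotoxicity (on this read-out higher numbers stand for lower toxicity in this test and lower numbers for higher toxicity in this test), compound 1 gives 78000 nM and stands at one end of a pair whose only step, a 1.3-fold higher number from compound 1 to compound 2 (0.10 log units; within the scatter), is within the scatter. Compound 3 `COc1ccccc1/C=C/C(=O)OCCc1c(-c2ccccc2Cl)c2cc(Cl)ccc2[nH]c1=O` differs from compound 1 by 2-(2-methoxyphenyl)ethenyl in place of heptyl on a carbonyl carbon. Within the data shown here, the one measured step at that carbonyl carbon, a 1.3-fold higher number from compound 1 to compound 2 (0.10 log units; within the scatter), exchanged the heptyl chain for a ring without moving beyond the scatter, so compound 3 is expected to stay close to compound 1 with a step of a 1.1-fold higher number from compound 1 to compound 3 (0.04 log units; within the scatter) not expected to exceed the scatter. Compound 3 is estimated at 85000 nM, within 45000 nM to 160000 nM.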

Compound 3, half-maximal cytotoxic concentration: 770000 nM
The estimate for compound 3 lay 9.1-fold (0.96 log units) below the measured number; measured number outside the range, above it.
By their numbers in this assay, from the lowest: compounds 1 and 2 (each within the scatter of the next); then compound 3.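

In this assay the group on this carbonyl carbon does move the read-out: 2-(2-methoxyphenyl)ethenyl gives a clear step over heptyl (a 9.9-fold higher number from compound 1 to compound 3 (0.99 log units; beyond the scatter)) and over furan-2-yl (a 7.9-fold higher number from compound 2 to compound 3 (0.90 log units; beyond the scatter)), although those two groups sit within the scatter of each other. An aromatic ring in this place is therefore not enough for such a step, as compound 2 shows. No evidence at hand bears on this result.

From the compounds shown here alone, whether the step belongs to the ethenyl link or to the 2-methoxyphenyl ring remains open. So does the effect of a plain phenyl ring or an amine at this carbonyl carbon.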